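The source may report more compounds than this note shows. Statements on the series, on what has been measured and on what is new or still open speak of the compounds shown alone.

Of the compounds shown here, three have been tested in an ADME assay on L1210/0 cells (Mus musculus) for cytotoxicity, with a stated time of 48 h; a higher number here means a weaker inhibitor, a lower number a stronger inhibitor. Compound 1 `CC1(C)[C@@H](Cn2nnc3c(Cl)nc(N)nc32)CC[C@@]1(C)CO` gives 44600 nM. Compound 2 `C=C(Cl)c1cn([C@H]2C[C@H](O)[C@@H](CO)O2)c(=O)[nH]c1=O` gives 1660 nM. Compound 3 `COc1cc(-c2cn([C@H]3C[C@H](O)[C@@H](CO)O3)c(=O)[nH]c2=O)c(OC)c(C)c1C` reaches only the limit of > 200000 nM, so for it no number is known, as the limit of > 200000 nM in this assay, at which 1 of the 3 values shown sits, shows. Of the two numbers that are known, compound 2 holds the lower, and its gap to compound 1 is well beyond the usual scatter of repeated measurements, so compound 2 is the stronger inhibitor of the two.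

Compound 4 `CC(C)(C)C#Cc1cn([C@H]2C[C@H](O)[C@@H](CO)O2)c(=O)[nH]c1=O` has not yet been measured in this assay. It differs from compound 2 in one place: 3,3-dimethylbut-1-yn-1-yl in place of 1-chloroethenyl on an aromatic carbon. Going by the values given here, no pair of the measured compounds differs by a single change, so no measured step here shows how an exchange of this kind shifts the number in this assay; the only hint is that compound 3, which carries a large group at the same place, sits at the limit.

The expected step in this assay is a 30-fold higher number from compound 2 to compound 4 (1.48 log units; beyond the scatter), toward a weaker inhibitor by more than the scatter. For compound 4 the estimated value in this assay is 50000 nM, with a range from 5000 nM to 200000 nM, and there is a fair chance that only a limit will be reported.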

Compound 4, half-maximal inhibitory concentration: > 200000 nM
Compound 4: no number, only a limit; the forecaster's own chance of this, stated with the estimate: 25%; middle value at least 4.0-fold (0.60 log units) from the limit.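

Exchanging 1-chloroethenyl for 3,3-dimethylbut-1-yn-1-yl on the aromatic carbon gives an at least 120-fold higher number from compound 2 to compound 4 (2.08 log units; beyond the scatter), the first single-change step available in this assay. This step shows directly that the group at this position can strongly change the measured cytotoxicity, although its printed size is only a minimum. Compound 3 also carries a large group at this position, and like compound 4 it gives only a limit, so on this shared core only compound 2, with its 1-chloroethenyl group, has a measured number: the limit of > 200000 nM in this assay, at which 2 of the 4 values shown sit.

With only one number on this core, the compounds shown cannot separate the effect of the number of heavy atoms in the new group from that of its triple bond or its branched end. A plain ethynyl group or a single bromine atom at the same position could show whether a number is kept with a smaller group, and a straight hexynyl chain could show whether the branching at the end of the group matters.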